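A few compounds are considered here, and "the series" means these few. Any claim that something is new, unique, unknown or untested is made for them only; others in the source may bear on it.

Compound 1 `COc1cc(O)c(C(=O)/C=C/c2ccc(F)cc2)c(OC)c1`: > 20000 nM
Compound 2 `COc1cc(OC)c(C(=O)/C=C/c2ccccc2SC)c(OC)c1`: 14100 nM
Compound 3 `COc1cc(O)c(C(=O)/C=C/c2ccccc2OC)c(OC)c1`: > 20000 nM

Among the measured compounds shown here, in a functional assay on Huh-7 cells (Homo sapiens) for cytotoxicity, with a stated time of 48 h (a lower number here means a stronger inhibitor, a higher number a weaker inhibitor), compound 2 gives 14100 nM, the only true number of the three. Compound 1 reads > 20000 nM, which is a limit of the assay and not a number. Compound 3 reads > 20000 nM, again a limit.

Compound 4 `COc1cc(OC)c(C(=O)/C=C/c2ccc(Cl)cc2)c(OC)c1` carries 4-chlorophenyl in place of 2-(methylsulfanyl)phenyl on a double-bonded chain carbon bound to a double-bonded chain carbon. For the measured compounds named here, no two measured compounds differ in one place only, and the size of this change is untested. In this assay, no step beyond the scatter is expected, in either direction. The estimate means a 1.2-fold lower number from compound 2 to compound 4 (0.07 log units; within the scatter). For compound 4 the estimated value is 12000 nM, with an expected range of 5000 nM to 20000 nM.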

Compound 4, half-maximal inhibitory concentration: 12700 nM
Compound 4: the middle estimate sits 1.1-fold (0.02 log units) below what was measured, within the range that was stated.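

In this assay, placing 4-chlorophenyl in place of 2-(methylsulfanyl)phenyl on a double-bonded chain carbon bound to a double-bonded chain carbon gives a 1.1-fold lower number from compound 2 to compound 4 (0.05 log units; within the scatter). Among the compounds shown here, this is the first pair that differs in one place only, and it shows that this exchange, with sulfur leaving and chlorine entering, leaves the read-out unchanged within the scatter. Two of the values shown are a limit of the assay and not a number: the limit of > 20000 nM in this assay, at which 2 of the 4 values shown sit.

Still open, going by these compounds, is whether an amine or a carboxylic acid at this position would move the value beyond the scatter. A single step also cannot show how other groups at this position would behave.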